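The source may hold more compounds than are shown below. What is called first, only, known or untested is meant among the compounds shown, and "the series" means these compounds.

Compound 1, `CCOc1cccc(C(CC)c2ccc(O)c(OC)c2)c1O`: 89%
Compound 2, `CCC(c1ccc(O)c(OC)c1)c1ccc(O)cc1O`: 85%

In a functional assay for inhibition, with a stated time of 18 h, tested at 100 ug/mL (a higher number here means more inhibition at the concentration tested (going by the name of the read-out), a lower number less inhibition), compound 1 gives 89%, the highest of the two numbers measured. Compound 2 gives 85% in this assay, a number that lies within the scatter of that of compound 1, so the two measured values show no order between them.

Compound 3, `CCC(c1ccc(O)c(OC)c1)c1cccc(C(C)C)c1O`, has not yet been measured. It differs from compound 1 in one place: isopropyl in place of ethoxy on an aromatic carbon. For the measured compounds named here, no measured step between any two of the measured compounds covers such a change, and the two measured values themselves sit within the scatter of each other, so the numbers at hand give no measured change of any size to lean on. Compound 3 is therefore expected to give about 84% in this assay, with an estimated range from 62% to 96%. The step of a number 5 percentage points lower from compound 1 to compound 3 (within the scatter) that this estimate means is expected to stay within the scatter.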

Compound 3, a percentage reported as inhibition, at one concentration (the size of the read-out at that concentration, not a potency): 88%
Estimate against measurement, compound 3: 4 percentage points below, and the stated range covers the measured number.
By their numbers in this assay, from the lowest: compounds 2, 3 and 1 (each within the scatter of the next).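

In this assay the exchange of ethoxy for isopropyl, on an aromatic carbon ortho to a hydroxy group and meta to a large group, gives a number 1 percentage points lower from compound 1 to compound 3 (within the scatter) and so stays inside the usual spread of repeat readings. For the compounds shown here, this is the only measured step at this position, and it shows that a group of 3 heavy atoms with a hydrogen-bond acceptor can give way to one of 3 carbon atoms with none, with no measurable change in the reading at the concentration tested. No measurement at hand accounts for this result.

On these data alone, whether a group of another kind at this position, such as an amine, a carboxylic acid or a longer chain, would leave the reading in this assay equally undisturbed stays open. Also open, as far as these compounds go, is whether the two groups would still match at lower concentrations.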